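Methyl Placed on the Core: Expectation for Compound 4

This account rests on a few compounds, and the source may have more. Where it says the series, first, only, none or still open, it means among the compounds named here.

Measured so far in a functional assay on the whole organism (strain Sprague-Dawley) for inhibition, with Rattus norvegicus as the target, read by paw edema, with stated times of 1 h and 3 h, at a dose of 50 mg/kg by the oral route; on this read-out higher numbers stand for more inhibition at the one dose given (going by the name of the read-out) and lower numbers for less inhibition:
compound 1 `CN(C)c1nc(N)sc1C(=O)c1cnc2ccccn12` gives 32%;
compound 2 `Cc1cccn2c(C(=O)c3sc(N)nc3N(C)C)cnc12` gives 81%;
compound 3 `Nc1ncc(C(=O)c2cnc3ccccn23)s1` gives 33%.

Compound 4 `Cc1ccn2c(C(=O)c3cnc(N)s3)cnc2c1` awaits measurement in this assay. Its change from compound 3 is methyl in place of hydrogen on an aromatic carbon. The same kind of change was made from compound 1 to compound 2, (methyl in place of hydrogen on an aromatic carbon), and there it gave a number 49 percentage points higher from compound 1 to compound 2 (beyond the scatter). The two places are not the same, though: in compound 2 the methyl stands ortho to a fused ring, two atoms from the ring nitrogen, meta to a fused ring, whereas in compound 4 it stands meta to a fused ring, opposite the ring nitrogen, para to a fused ring. The cores of compound 1 and compound 3 differ by hydrogen in place of dimethylamino on an aromatic carbon, a change that gave a number 1 percentage points higher from compound 1 to compound 3 (within the scatter).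

An expected step of a number 22 percentage points higher from compound 3 to compound 4 (beyond the scatter) seems reasonable for compound 4, held below the earlier one because a number 49 percentage points higher from compound 1 to compound 2 (beyond the scatter) was seen at another place on the ring. Compound 4 is therefore estimated at 55%, expected to fall between 30% and 80%.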

Compound 4, a percentage reported as inhibition, in the whole organism at one dose (the size of the read-out at that dose, not a potency): 77%
Beside the measured number, compound 4's estimate is 22 percentage points below it; measured number inside the range.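

Placing methyl on the ring gave a number 44 percentage points higher from compound 3 to compound 4 (beyond the scatter) in this assay. The step carried over between the core with dimethylamino and the core without it, at much the same size: the same change on two cores in this assay, a number 49 percentage points higher (beyond the scatter) from compound 1 to compound 2 and a number 44 percentage points higher (beyond the scatter) from compound 3 to compound 4, 5 percentage points apart, within the scatter of two such steps

The methyl stands at a different place in compound 2 and compound 4, so the match does not show how either place would behave on the other core, and two pairs set no general rule for the series.

The compounds shown leave open whether ethyl, a longer chain or methoxy at the place opposite the ring nitrogen would give a step of this size. They also leave open what an amine or a carboxylic acid there would do.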